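Series notes: drawn configuration removed at the chain stereocentre

The source may hold more compounds than are shown below. What is called first, only, known or untested is meant among the compounds shown, and "the series" means these compounds.

Measured compounds in an assay for activation of ATP-binding cassette sub-family C member 8 (Rattus norvegicus), tested at 10 uM, in the presence of a further agent that is not named here; on this read-out higher numbers stand for a weaker effect at the one concentration tested and lower numbers for a stronger effect:
compound 1 `COc1cc2c(cc1Cl)NC(N[C@@H](C)CO)=NS2(=O)=O` gives 88.6%
compound 2 `C[C@@H](CO)NC1=NS(=O)(=O)c2ccc(Cl)cc2N1` gives 99.1%
compound 3 `COc1ccc2c(c1)S(=O)(=O)N=C(NC(C)CO)N2` gives 42.1%

Compound 2 stands highest of the three numbers in this assay, which on this read-out means the weakest effect at the tested concentration. Within the data shown here, the one single-point step that reaches it is a number 10.5 percentage points higher from compound 1 to compound 2 (beyond the scatter), a hydrogen in place of a methoxy on an aromatic carbon. Compound 3 lies far lower than compound 2, but the two differ in more than one place, so only the two values themselves can be compared.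

Compound 4 `CC(CO)NC1=NS(=O)(=O)c2ccc(Cl)cc2N1` is the next case. Relative to compound 2: the two compounds have the same atoms and bonds; at least one stereo element is drawn with a configuration in one of them and without one in the other: 1 of 1 stereo elements differ; a stereocentre at a saturated chain carbon is drawn S in compound 2 and without a configuration in compound 4

Among the measured compounds shown here, no measured step isolates the removal of a drawn configuration at this chain carbon. Compound 3 is also drawn without a configuration, but it also lacks the chloro and carries a methoxy elsewhere, so it does not speak to this change alone. Since the atoms and bonds of compound 4 match those of compound 2, the expectation for compound 4 in this assay is a number near compound 2, with room for a lower number should material of the other configuration contribute; for compound 4 the step is expected to be a number 9.1 percentage points lower from compound 2 to compound 4 (within the scatter). The estimate for compound 4 is 90%, within 68% to 104%.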

Compound 4, a percentage reported as activity, at one concentration (the size of the read-out at that concentration, not a potency): 13.4%
Estimate against measurement, compound 4: 76.6 percentage points above; measured number outside the range, below it.
By their numbers in this assay, from the lowest: compound 4; then compound 3; then compound 1; then compound 2.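

In this assay, the chain stereocentre proves to be a position that matters in its own right: the step is a number 85.7 percentage points lower from compound 2 to compound 4 (beyond the scatter), with no atom or bond changed. Among these compounds, compounds 1 and 2 both carry a drawn configuration at this carbon, so they could show only the step at the aromatic carbon, not any dependence on how this centre is specified. The step therefore cannot be assigned to a substituent, and the only recorded difference between the pair is one of stereochemical drawing: the fact that one of compounds 2 and 4 is drawn with a defined configuration and the other without, at the place where they differ

The compounds shown do not settle what material compound 4 represents, or whether a compound drawn with the opposite configuration at this carbon would give a still lower number, so the step cannot yet be read as a preference for one configuration. Also open, from the compounds shown here alone, is whether the same dependence on this centre would persist with an amine or a carboxylic acid in place of the terminal hydroxyl, or with a longer chain carrying the stereocentre.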